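A few compounds are considered here, and "the series" means these few. Any claim that something is new, unique, unknown or untested is made for them only; others in the source may bear on it.

Working notes on the series. Compound 1 `COc1ncnc2c1c(-c1cccs1)cn2[C@@H]1O[C@H](CO)[C@@H](O)[C@H]1O` and compound 3 `COc1ncnc2c1c(-c1ccccc1)cn2[C@@H]1O[C@H](CO)[C@@H](O)[C@H]1O` share one core; compound 2 `Nc1nc(N)c2c(-c3ccccc3)cn([C@@H]3O[C@H](CO)[C@@H](O)[C@H]3O)c2n1` and compound 4 `Nc1nc(N)c2c(-c3cccs3)cn([C@@H]3O[C@H](CO)[C@@H](O)[C@H]3O)c2n1` share another, and the difference between the two cores is not broken down here. In a functional assay on A549 cells (Homo sapiens), read by MTT assay, with a stated time of 72 h (a higher number here means a weaker inhibitor, a lower number a stronger inhibitor), compound 1 gives 4850 nM. Compound 3 reaches only a limit of this assay, > 20000 nM. Compound 2 likewise stops at a limit, > 20000 nM. Going by these compounds, the change thiophen-2-yl in place of phenyl on an aromatic carbon produced an at least 4.1-fold lower number from compound 3 to compound 1 (0.61 log units; beyond the scatter); its true size stays open because of the limit of > 20000 nM in this assay, at which 2 of the 3 values shown sit. Compound 4 carries the same change, (thiophen-2-yl in place of phenyl on an aromatic carbon), on the other core. For compound 4 a step of roughly an at least 2.5-fold lower number from compound 2 to compound 4 (0.39 log units; beyond the scatter) is expected, resting on an at least 4.1-fold lower number from compound 3 to compound 1 (0.61 log units; beyond the scatter). The starting point of compound 2 being a limit, the expected outcome of compound 4 in this assay is 8000 nM, estimated between 3000 nM and 25000 nM, with a real chance that only a limit is reported.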

Compound 4, half-maximal inhibitory concentration: > 20000 nM
Compound 4 gave a limit, no number; the forecaster's own chance of this, stated with the estimate: 35%; at least 2.5-fold (0.39 log units) between middle value and limit.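

Compound 2 and compound 4 both stop at a limit in this assay, so no step between them can be read: the limit of > 20000 nM in this assay, at which 3 of the 4 values shown sit.

Going by these compounds, whether thiophen-2-yl in place of phenyl lowers the number on the core of compound 2 stays open.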